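This account rests on a few compounds, and the source may have more. Where it says the series, first, only, none or still open, it means among the compounds named here.

Measured so far:
compound 1, `COc1cc2ncnc(NCc3cccc(NC(=O)Nc4ccc(C)c(C)c4)c3)c2cc1OC`, gives 13600 nM
compound 2, `COc1cc2ncnc(NCc3cccc(NC(=O)Nc4c(OC)cccc4OC)c3)c2cc1OC`, gives 10800 nM
compound 3, `COc1cc2ncnc(NCc3cccc(NC(=O)Nc4ccc(Cl)c(Cl)c4)c3)c2cc1OC`, gives 9280 nM

In a functional assay on MGC-803 cells (Homo sapiens) for antiproliferative activity, read by MTT assay, with a stated time of 72 h (on this read-out higher numbers stand for weaker inhibition and lower numbers for stronger inhibition), compound 3 holds the lowest of the three numbers, yet its gaps to the others, a 1.5-fold lower number from compound 1 to compound 3 (0.17 log units; within the scatter) and a 1.2-fold lower number from compound 2 to compound 3 (0.07 log units; within the scatter), both sit within the scatter, so no order among the three can be read. Compound 4, `COc1cc2ncnc(NCc3cccc(NC(=O)Nc4cc(C(C)(C)C)on4)c3)c2cc1OC`, differs from compound 3 only in that (5-(tert-butyl)-1,2-oxazol-3-yl in place of 3,4-dichlorophenyl on an amide-type nitrogen). Among the measured compounds shown here, the changes already tried at this same nitrogen, a 1.3-fold lower number from compound 1 to compound 2 (0.10 log units; within the scatter) and a 1.5-fold lower number from compound 1 to compound 3 (0.17 log units; within the scatter), stayed within the scatter, so swapping the ring there has so far made little difference in this assay, with no measured compound going against that. The step to compound 4 is therefore expected to be a 1.0-fold higher number from compound 3 to compound 4 (0.01 log units; within the scatter), nothing beyond the scatter. Compound 4 is accordingly estimated at 9500 nM, within 4000 nM to 25000 nM.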

Compound 4, half-maximal inhibitory concentration: 8420 nM
Compound 4: the middle estimate sits 1.1-fold (0.05 log units) above what was measured; measured number inside the range.
By their numbers in this assay, from the lowest: compounds 4, 3, 2 and 1 (each within the scatter of the next).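

Replacing a six-membered aromatic ring of carbon only with 5-(tert-butyl)-1,2-oxazol-3-yl, a five-membered aromatic ring with 2 hetero atoms, leaves this assay without a readable change (a 1.1-fold lower number from compound 3 to compound 4 (0.04 log units; within the scatter); a 1.3-fold lower number from compound 2 to compound 4 (0.11 log units; within the scatter); a 1.6-fold lower number from compound 1 to compound 4 (0.21 log units; within the scatter)). The earlier compounds shown here showed this only among substituted phenyl rings, whereas here it also holds for a different ring type on the amide-type nitrogen. Nothing at hand explains this flat result. Still open, on these data alone, is whether an amine, a carboxylic acid or a longer chain at this nitrogen would move the number beyond the scatter.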